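From compound 3 to compound 4: carboxy replaced

The compounds below may be only part of what the source reports. "The series", "measured", "known", "first", "only" and "open" are said of these compounds alone.

Of the compounds shown here, three have been read in an assay for inhibition of 15-hydroxyprostaglandin dehydrogenase [NAD(+)] (Homo sapiens), read by fluorescence, with a stated time of 15 min, in the presence of a further agent that is not named here; on this read-out higher numbers stand for weaker inhibition and lower numbers for stronger inhibition. Compound 1 `Nc1c([S+]([O-])CCCF)sc2nc(-c3cccs3)cc(-c3ccccc3)c12` gives 6.1 nM in this assay. Compound 2 `CCCC[S+]([O-])c1cc2c(-c3ccccc3)nc(-c3ccccc3)nc2s1`, built on a different core, gives 93 nM in this assay. Compound 3 `Nc1c(C(=O)O)sc2nc(-c3cccs3)cc(-c3ccccc3)c12` reaches only a limit of this assay, > 7500 nM, so its value is known merely as a limit (the limit of > 7500 nM in this assay, at which 1 of the 3 values shown sits), and it stands at the weak end of the numbers shown.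

Compound 4 `CCCCCC[S+]([O-])c1sc2nc(-c3cccs3)cc(-c3ccccc3)c2c1N` is not yet measured. Relative to compound 3 the change is a group of 8 heavy atoms (6 carbon, 1 oxygen, 1 sulfur; no ring) in place of a group of 3 heavy atoms (1 carbon, 2 oxygen; no ring), on an aromatic carbon. Among the compounds with values here, the one measured step that bears on it runs the other way: an at least 1200-fold higher number from compound 1 to compound 3 (3.08 log units; beyond the scatter), where a carboxy group took the place of a chain carrying oxygen and sulfur on the same aromatic carbon. Restoring such a chain in compound 4 is therefore expected to give a large step to a lower number, an at least 500-fold lower number from compound 3 to compound 4 (2.69 log units; beyond the scatter), in this assay, with the hexyl length of the new chain adding uncertainty beside the fluoropropyl chain of compound 1 6.1 nM. For compound 4 the expected value in this assay is 15 nM, with a range from 3 nM to 120 nM.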

Compound 4, half-maximal inhibitory concentration: 18 nM
For compound 4 the middle estimate is 1.2-fold (0.08 log units) below the measured one; low and high end bracket the measured number.
By their numbers in this assay, from the lowest: compound 1; then compound 4; then compound 2. At a limit, above all of these: compound 3.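

On the aromatic carbon next to the ring sulfur, the chain of compound 4 in place of carboxy gives an at least 410-fold lower number from compound 3 to compound 4 (2.61 log units; beyond the scatter) in this assay, so a low number at this position is not confined to the fluoropropyl chain of compound 1. Compound 3 has only a limit, so the size of that step is a bound: the limit of > 7500 nM in this assay, at which 1 of the 4 values shown sits. Between the two chains the change is far smaller, with a 3.0-fold higher number from compound 1 to compound 4 (0.47 log units; beyond the scatter), so on this core the difference between the chains is modest but still beyond the scatter.

On these data alone, how a shorter chain such as ethyl or a longer chain such as octyl would read on this core remains open. So does whether an amine or a primary amide on this carbon would read nearer to the chains or to carboxy.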